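Swapping benzyloxy for chloro on an inactive benzylamine

A few compounds are considered here, and "the series" means these few. Any claim that something is new, unique, unknown or untested is made for them only; others in the source may bear on it.

Measured so far in an assay for inhibition of Indoleamine 2,3-dioxygenase 1 (Homo sapiens), with stated times of 10 min and 60 min; a higher number here means a weaker inhibitor, a lower number a stronger inhibitor:
Compound 1, `O=C1NC(=O)c2c(NCc3ccccc3[N+](=O)[O-])cccc21`, gives > 100000 nM, a limit of the assay.
Compound 2, `O=[N+]([O-])c1cc(OCc2ccccc2)ccc1CNc1cc(C(F)(F)F)cc2[nH]ncc12`, gives > 100000 nM, also a limit.
Compound 3, `O=[N+]([O-])c1cccc(CNc2cc(Br)cc3[nH]ncc23)c1`, gives 7950 nM.

Compound 2 therefore stands at the limit of > 100000 nM in this assay, at which 2 of the 3 values shown sit, so no inhibition was measured for it within the range the assay covers. Compound 3, which carries a bromo on the core and no benzyloxy, does give a measurable number, and compound 1, on a different core, again sits at the limit.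

Compound 4, `O=[N+]([O-])c1cc(Cl)ccc1CNc1cc(C(F)(F)F)cc2[nH]ncc12`, is the untested compound, and it differs from compound 2 in one place: chloro in place of benzyloxy on an aromatic carbon. Among the measured compounds shown here, since no two measured compounds differ in a single place, no measured step tells how large an effect this change has. The expectation is a gain in potency beyond the scatter, though an uncertain one, because compound 3 gives 7950 nM without the benzyloxy group. Compound 4 is thus expected to come in around 30000 nM, somewhere between 5000 nM and 200000 nM. The step that this estimate implies is an at least 3.3-fold lower number from compound 2 to compound 4 (0.52 log units; beyond the scatter), with a real chance that the assay again returns only a limit.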

Compound 4, half-maximal inhibitory concentration: 18000 nM
Estimate against measurement, compound 4: 1.7-fold (0.22 log units) above; the measured number falls inside the stated range.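

In this assay, chloro in place of benzyloxy on an aromatic carbon gives an at least 5.5-fold lower number from compound 2 to compound 4 (0.74 log units; beyond the scatter). This size is only a lower bound, because compound 2 has no measured number of its own, only a limit of the assay: the limit of > 100000 nM in this assay, at which 2 of the 4 values shown sit. This is the first pair shown that differs in one place, and it shows that on the shared core, the group on this carbon, meta to a nitro group, can decide whether inhibition becomes measurable at all, with the eight heavy atoms and the ring of benzyloxy giving way to a single chlorine.

From the compounds shown here alone, what remains open is whether the gain comes from losing benzyloxy or from gaining chloro, a question that a methoxy group, an amine or a plain hydrogen on the same carbon could help to settle. Also open is what the trifluoromethyl group on the core and the nitro group contribute, as no pair shown changes only one of these groups.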